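Swapping a fluorophenyl for a thiazole on the amide

The source may report more compounds than this note shows. Statements on the series, on what has been measured and on what is new or still open speak of the compounds shown alone.

Three compounds share one core and differ only in the group on the carbonyl carbon of the amide. Compound 1 `CCC(=O)N1CCCn2nc(COc3ccccc3)cc21` carries an ethyl there, compound 2 `O=C(c1cccc(F)c1)N1CCCn2nc(COc3ccccc3)cc21` a 3-fluorophenyl, and compound 3 `O=C(c1ccc(F)cc1)N1CCCn2nc(COc3ccccc3)cc21` a 4-fluorophenyl. In a functional assay on HEK293 cells for positive allosteric modulation of metabotropic glutamate receptor 5 (Homo sapiens), read by calcium flux (on this read-out lower numbers stand for smaller maximal responses and higher numbers for larger maximal responses), compound 1 gives 48%, compound 2 gives 61%, and compound 3 gives 63%. Compound 3 thus has the highest of the three numbers, though its difference from compound 2, a number 2 percentage points higher from compound 2 to compound 3 (within the scatter), lies within the scatter; only a number 15 percentage points higher from compound 1 to compound 3 (beyond the scatter) is a step beyond it. Together with a number 13 percentage points higher from compound 1 to compound 2 (beyond the scatter), these steps show that either fluorophenyl on the carbonyl carbon gives a larger maximal response than ethyl, while moving the fluorine changes nothing beyond the scatter.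

Compound 4 `O=C(c1nccs1)N1CCCn2nc(COc3ccccc3)cc21` is not yet measured. It differs from compound 3 in one place: 1,3-thiazol-2-yl in place of 4-fluorophenyl on a carbonyl carbon. Among the compounds with values here, no measured step swaps one aromatic ring for another of a different kind, so the fluorophenyl steps bear on this change only loosely: they say an aromatic ring on this carbon beats a short chain, but not how a five-membered ring with two hetero atoms compares with a six-membered ring of carbon only. A modest step in this assay in either direction, or none beyond the scatter, is therefore expected. The expected step is a number 5 percentage points lower from compound 3 to compound 4 (within the scatter). Compound 4 is estimated at 58%, within 40% to 75%.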

Compound 4, largest response reached (reported as percent of maximum), in percent of the reference or control that the assay uses: 24%
Compound 4: the middle estimate sits 34 percentage points above what was measured, outside the stated range (below it).
By their numbers in this assay, from the lowest: compound 4; then compound 1; then compounds 2 and 3 (each within the scatter of the next).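

This result shows that an aromatic ring on this carbonyl carbon does not by itself give a larger maximal response in this assay: the change to 1,3-thiazol-2-yl brings a number 39 percentage points lower from compound 3 to compound 4 (beyond the scatter) and a number 37 percentage points lower from compound 2 to compound 4 (beyond the scatter), and it even falls short of the short chain, with a number 24 percentage points lower from compound 1 to compound 4 (beyond the scatter). The earlier rule that a ring beats ethyl therefore holds only for the two fluorophenyl compounds, and compound 4 goes against it, so the kind of ring at this position matters far more than the place of the fluorine did. Nothing available here explains this fall, and the change alters several things at once, from a six-membered ring of carbon only with 0 hydrogen-bond acceptors to a five-membered ring with 2 hetero atoms and 2 hydrogen-bond acceptors.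

The compounds shown leave open which of these differences counts, since none separates ring size from the hetero atoms. A pyridine ring would keep six members while adding a nitrogen, and a thiophene ring would keep five members with sulfur alone, so each would test one part of the change.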